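A few compounds are considered here, and "the series" means these few. Any claim that something is new, unique, unknown or untested is made for them only; others in the source may bear on it.

Compound 3, `CC(C)(N)C(=O)N[C@H](COCc1ccccc1)c1nnn(Cc2ccccc2)n1`, is measured in an assay on isolated protein for displacement of a labelled ligand from growth hormone secretagogue receptor type 1 (Homo sapiens), with a stated time of 1 h (a lower number here means a stronger inhibitor, a higher number a weaker inhibitor), where compound 3 gives 4750 nM. Of the two numbers available, that of compound 3 is the higher; the gap to compound 2 lies beyond the scatter of the measurement. Compound 2, `CN(c1ccccc1CCCn1nnnc1[C@@H](COCc1ccccc1)NC(=O)C(C)(C)N)S(C)(=O)=O`, carries the same amide and ether portion on a differently built attachment to the core, and in this assay compound 2 gives 1720 nM. Compound 1, `CC(C)(N)C(=O)N[C@H](COCc1ccccc1)c1nnnn1Cc1ccc(NS(C)(=O)=O)cc1`, reaches only a limit of the assay, giving > 5000 nM, which is the limit of > 5000 nM in this assay, at which 1 of the 3 values shown sits. Compound 4, `CC(C)(N)C(=O)N[C@H](COCc1ccccc1)c1nnn(CC#N)n1`, has not been measured in this assay. It differs from compound 3 by cyano in place of phenyl on a saturated chain carbon bound to an aromatic nitrogen, so the benzyl group on the tetrazole nitrogen becomes a cyanomethyl group. Among the measured compounds shown here, the measured compounds offer no direct guide for the loss of this phenyl, and no step between them repeats it. The step from compound 3 to compound 4 is expected to be a 1.7-fold higher number from compound 3 to compound 4 (0.23 log units; within the scatter), towards a weaker binder, with a fair chance that only a limit is recorded. Compound 4 is therefore estimated at 8000 nM, within a range from 3000 nM to 25000 nM.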

Compound 4, inhibition constant: > 5000 nM
Compound 4: a limit, no number; the forecaster's own chance of this, stated with the estimate: 55%; the middle value lies beyond the limit too.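

In this assay compound 4 gives > 5000 nM, which is a limit of the assay and not a number. With cyano in place of phenyl on a saturated chain carbon bound to an aromatic nitrogen, the change can be read only as a floor, an at least 1.0-fold higher number from compound 3 to compound 4 (0.02 log units; that floor lies within the scatter), so the result shows no gain in binding from this change but cannot show whether it causes any loss. Any larger loss would stay hidden at the same ceiling: the limit of > 5000 nM in this assay, at which 2 of the 4 values shown sit.

From the compounds shown here alone, how far binding falls once the benzyl group gives way to cyanomethyl remains open. Also open, going by these compounds, is whether a carboxylic acid or an amine in place of cyano on this chain carbon would give a number rather than a limit.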